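This account rests on a few compounds, and the source may have more. Where it says the series, first, only, none or still open, it means among the compounds named here.

The measured compounds are:

Compound 1, `CCc1cc(=O)c2ccc(Sc3cccc(Cl)[n+]3[O-])cc2o1`; in a functional assay on KBVIN cells (Homo sapiens) for antiproliferative activity, read by sulforhodamine B assay, with a stated time of 72 h (a lower number here means a stronger inhibitor of growth, a higher number a weaker inhibitor of growth), compound 1 gives only a limit of the assay, > 29900 nM.
Compound 2, `CCc1cc(=O)c2ccc(Sc3cccc(Cl)[n+]3[O-])c(C)c2o1`; in this assay compound 2 gives only a limit of the assay, > 28700 nM.
Compound 3, `CCc1cc(=O)c2ccc(Sc3cccc(Cl)n3)cc2o1`; in this assay compound 3 gives only a limit of the assay, > 31400 nM.

Compound 1 and compound 2 differ in one place, (methyl in place of hydrogen on an aromatic carbon). The step that the two limits leave unreadable from compound 1 to compound 2 cannot be read because the limit of > 29900 nM in this assay, at which 1 of the 3 values shown sits, and the limit of > 28700 nM in this assay, at which 1 of the 3 values shown sits, each record only a ceiling of the measurement and no point value. How the core of compound 3 differs from the core of compound 1 is not broken down here. Compound 3 also sits at a ceiling, as the limit of > 31400 nM in this assay, at which 1 of the 3 values shown sits, records.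

Compound 4, `CCc1cc(=O)c2ccc(Sc3cccc(Cl)n3)c(C)c2o1`, has not yet been measured. It differs from compound 3 by methyl in place of hydrogen on an aromatic carbon. Compared with the change from compound 1 to compound 2, the surroundings differ in one respect: in compound 4 the methyl is ortho to a group of 8 heavy atoms, whereas in compound 2 it is ortho to a group of 9 heavy atoms. It is therefore the same kind of change, not the same one.

In this assay the expected step is a step that the limit leaves unreadable from compound 3 to compound 4, and this expectation rests on the unreadable step that the two limits leave unreadable from compound 1 to compound 2, which gives no sign that the methyl moves the value away from the ceiling. Compound 4 is expected to give 45000 nM in this assay, most likely again only a limit, with a range from 15000 nM to 200000 nM.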

Compound 4, concentration for 50% growth inhibition: 23900 nM
Compound 4: middle estimate off by 1.9-fold (0.27 log units), on the high side, and the stated range covers the measured number.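

In this assay, placing a methyl in place of hydrogen on an aromatic carbon of the core of compound 3 gives an at least 1.3-fold lower number from compound 3 to compound 4 (0.11 log units; that floor lies within the scatter), so the printed floor alone does not show a real gain, although the true step may be larger than that floor. Compound 4 gives 23900 nM, a point value and not a limit, which shows that this methyl-bearing compound can be read in this assay, but it does not show that the methyl has the same effect on every core in this series. The matching step on the core of compound 1 cannot be read, so the two cores cannot be compared for this change, and the size of the new step stays open because compound 3 records only a limit: the limit of > 31400 nM in this assay, at which 1 of the 4 values shown sits.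

The compounds shown leave open whether a larger group on that same aromatic carbon, such as a propyl chain, a methoxy group or an amine, would lower the number further or raise it. They also leave open what would happen if the chlorine on the sulfur-linked ring gave way to a carboxylic acid or an amine.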